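The source may hold more compounds than are shown below. What is called first, only, known or untested is meant among the compounds shown, and "the series" means these compounds.

Measured compounds:
- compound 1 `COc1ncc(-c2ccc3ncnc(Nc4ccc(OCCO)cc4)c3c2)cc1NS(=O)(=O)c1ccc(F)cc1F` gives 1650 nM
- compound 2 `COc1ncc(-c2ccc3ncnc(Nc4cnn(CCC(=O)O)c4)c3c2)cc1NS(C)(=O)=O` gives 560 nM

Both values come from a functional assay on MCF7 cells (Homo sapiens) for antiproliferative activity, read by sulforhodamine B assay, with a stated time of 72 h; a lower number here means a stronger inhibitor, a higher number a weaker inhibitor. Compound 1 holds the highest of the two numbers; compound 2 sits at a lower number, and the gap between them is beyond the usual scatter. For the measured compounds named here, no single-change step between measured compounds exists, so the two values only show that compound 2, which differs from compound 1 in more than one place, inhibits more strongly.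

Compound 3 `COc1ncc(-c2ccc3ncnc(Nc4cnn(CCCO)c4)c3c2)cc1NS(=O)(=O)c1ccc(F)cc1F` is not yet measured. It differs from compound 1 in one place: 1-(3-hydroxypropyl)-1H-pyrazol-4-yl in place of 4-(2-hydroxyethoxy)phenyl on a nitrogen on an aromatic ring. The new group is the same kind of five-membered ring carried by compound 2, with a hydroxypropyl chain in place of the acid-bearing chain, while the rest of compound 1 is kept.

Given that compound 2 gives 560 nM with such a ring, a moderate move toward lower numbers is expected for compound 3 in this assay, of the size a 1.8-fold lower number from compound 1 to compound 3 (0.26 log units; within the scatter), though it may not exceed the scatter. The estimate for compound 3 is 900 nM, within 300 nM to 2700 nM.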

Compound 3, half-maximal inhibitory concentration: 1310 nM
Compound 3: middle estimate off by 1.5-fold (0.16 log units), on the low side; low and high end bracket the measured number.
By their numbers in this assay, from the lowest: compound 2; then compounds 3 and 1 (each within the scatter of the next).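

In this assay, the exchange on a nitrogen on an aromatic ring gives a 1.3-fold lower number from compound 1 to compound 3 (0.10 log units; within the scatter), so 1-(3-hydroxypropyl)-1H-pyrazol-4-yl and 4-(2-hydroxyethoxy)phenyl cannot be told apart at this position. With the rest of compound 1 kept, a five-membered aromatic ring with 2 hetero atoms can stand in place of a six-membered aromatic ring of carbon only, and the step stays within the scatter. Nothing available here bears on why the two groups read alike.

Compound 2, at 560 nM, differs from compound 3 in both the end of the chain on the pyrazole and the group on the sulfonamide, so these compounds do not separate the contributions of the acid-bearing chain and the sulfonamide group. Also open, as far as these compounds go, is how the value in this assay responds to a terminal amine in place of the hydroxyl on the propyl chain, or to a longer chain on the pyrazole, with the sulfonamide group of compound 3 kept.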